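Notes on an amide nitrogen replacement

The source may report more compounds than this note shows. Statements on the series, on what has been measured and on what is new or still open speak of the compounds shown alone.

Measured in a physicochemical assay for lipophilicity, at pH 7.4; a higher number here means a more lipophilic compound, a lower number a more polar compound:
- compound 1 `CNC(=O)c1cc(C(=O)N[C@H]2[C@@H]3COC[C@@H]32)cc2c1OC[C@H]2c1cccc2[nH]ccc12`: 3.1
- compound 2 `CCC(=O)N1C[C@@H]2[C@H](C1)[C@H]2NC(=O)c1cc(C(=O)NC)c2c(c1)[C@H](c1ccccc1)CO2`: 3.4

Compound 2 gives 3.4, which lies within the scatter of compound 1 at 3.1. The next structure is compound 3 `CNC(=O)c1cc(C(=O)Nc2cnn(C)c2)cc2c1OC[C@H]2c1ccccc1`, and the change is a group of 6 heavy atoms (4 carbon, 2 nitrogen; one five-membered aromatic ring with 2 hetero atoms) in place of a group of 10 heavy atoms (8 carbon, 1 nitrogen, 1 oxygen; one three-membered non-aromatic ring of carbon only, one five-membered non-aromatic ring with 1 hetero atom), on an amide-type nitrogen. It places 1-methyl-1H-pyrazol-4-yl on an amide-type nitrogen. Going by the values given here, no measured pair differs in one place only, so the data give no direct size for this step. The two measured compounds differ in more than one place, yet their values in this assay stay within the scatter of each other. A modest downward step a number 0.40 log units lower from compound 2 to compound 3 (beyond the scatter) is expected, and this estimate is uncertain. For compound 3 the estimated value is 3, with an expected range of 2.5 to 3.5.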

Compound 3, distribution coefficient: 3.5
For compound 3 the middle estimate is 0.50 log units below the measured one; the range from low to high includes it.
By their numbers in this assay, from the lowest: compounds 1, 2 and 3 (each within the scatter of the next, the first and the last beyond it).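

In this assay, going by these compounds alone, 1-methyl-1H-pyrazol-4-yl in place of the group of 10 heavy atoms on the amide-type nitrogen gives a number 0.10 log units higher from compound 2 to compound 3 (within the scatter), the only step that can be read at a single place. At this position, with the rest of the structure shared, the group with its three-membered and five-membered non-aromatic rings and the aromatic 1-methyl-1H-pyrazol-4-yl cannot be told apart in this read-out, despite the difference in heavy atoms and ring type. Nothing in the available data accounts for this result.

On these data alone, whether the same holds for other groups on this nitrogen, such as a piperidine, a carboxylic acid or a longer alkyl chain, stays open. Within the data shown here, compound 1 differs from compound 2 and compound 3 in more than one place, so it gives no separate step for this position.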